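Anilino series on a shared core: halogen steps in cell inhibition

This account rests on a few compounds, and the source may have more. Where it says the series, first, only, none or still open, it means among the compounds named here.

Measured compounds:
- compound 1, `Cc1ccc(NC2=CC(=O)c3c(nc4n3[C@H]3OC[C@@H](O)[C@H]3OC4)C2=O)cc1`: in a functional assay on ECa-109 cells for inhibition, with ECa-109 cell line (Homo sapiens) as the target, read by sulforhodamine B assay (on this read-out higher numbers stand for weaker inhibition and lower numbers for stronger inhibition), compound 1 gives > 4000 nM, which is a limit of the assay and not a number.
- compound 2, `O=C1C=C(Nc2ccccc2)C(=O)c2c1nc1n2[C@H]2OC[C@@H](O)[C@H]2OC1`: in this assay compound 2 gives 4970 nM.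
- compound 3, `O=C1C=C(Nc2ccc(I)cc2)C(=O)c2c1nc1n2[C@H]2OC[C@@H](O)[C@H]2OC1`: in this assay compound 3 gives 2300 nM.

Compound 1 thus stands only at a limit (the limit of > 4000 nM in this assay, at which 1 of the 3 values shown sits), with no number of its own; compounds 2 and 3 carry the two numbers in the set. Among the measured compounds shown here, the one measured step, a 2.2-fold lower number from compound 2 to compound 3 (0.33 log units; beyond the scatter), shows that a halogen on the anilino ring moves the read-out down by a modest amount.

Compound 4, `O=C1C(Nc2cccc(Cl)c2)=CC(=O)c2c1nc1n2[C@H]2OC[C@@H](O)[C@H]2OC1`, is not yet measured. It differs from compound 1 by 3-chlorophenyl in place of 4-methylphenyl on an amine nitrogen. The step from compound 2 to compound 3 is the nearest guide, as it also puts a halogen on this ring and gave a modest gain; the methyl of compound 1 gives no number to anchor from. A step of similar size in the same direction is therefore expected, an at least 1.3-fold lower number from compound 1 to compound 4 (0.12 log units; that floor lies within the scatter), though the limit on compound 1 leaves this uncertain. Compound 4 is estimated at 3000 nM, with a range from 1200 nM to 7500 nM.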

Compound 4, half-maximal inhibitory concentration: 3080 nM
Estimate against measurement, compound 4: 1.0-fold (0.01 log units) below, within the range that was stated.
By their numbers in this assay, from the lowest: compounds 3, 4 and 2 (each within the scatter of the next, the first and the last beyond it).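

The step to the 3-chlorophenyl group on the amine nitrogen reads as an at least 1.2-fold lower number from compound 1 to compound 4 (0.11 log units; that floor lies within the scatter) and so cannot be claimed as a firm gain over the 4-methylphenyl group. In this assay compound 2 gives 4970 nM and compound 4 gives 3080 nM and these two values lie within the scatter of each other, so 3-chlorophenyl on this nitrogen does not separate from the plain phenyl, whereas the iodo step gave a 2.2-fold lower number from compound 2 to compound 3 (0.33 log units; beyond the scatter) and lay beyond the scatter. On these data alone, the true size of the step from the 4-methylphenyl compound stays unknown because compound 1 carries only a limit and not a number: the limit of > 4000 nM in this assay, at which 1 of the 4 values shown sits.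

Compounds 3 and 4 differ both in the halogen and in its place on the ring. The data do not tell these two differences apart. As far as these compounds go, how a carboxylic acid or an amine on the phenyl ring would read in this assay also remains open.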